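From butyl to propyl: working notes on compound 3

The source may hold more compounds than are shown below. What is called first, only, known or untested is meant among the compounds shown, and "the series" means these compounds.

Measured in a functional assay on A549 cells (Homo sapiens) for cytotoxicity, read by MTT assay, with a stated time of 72 h; a lower number here means a stronger inhibitor, a higher number a weaker inhibitor:
- compound 1 `CC(C)OC1OC(=O)C(Cl)=C1Cl`: 6700 nM
- compound 2 `CCCCOC1OC(=O)C(Cl)=C1Cl`: 22500 nM

Of the two measured compounds, compound 2 has the higher number, and its gap to compound 1 lies beyond the scatter. The next structure is compound 3 `CCCOC1OC(=O)C(Cl)=C1Cl`, which keeps the shared core and shortens the chain: hydrogen in place of methyl on a saturated chain carbon, three bonds along the chain from an oxygen on a saturated carbon. In words, this is hydrogen in place of methyl on a saturated chain carbon, three bonds along the chain from an oxygen on a saturated carbon, or butyl to propyl.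

Among the compounds with values here, the only measured step bearing on this change is a 3.4-fold higher number from compound 1 to compound 2 (0.53 log units; beyond the scatter), with butyl in place of isopropyl. That step is modest and exchanges a different pair of groups, so it is only a loose guide. A move to a lower number is expected in this assay, smaller than that step and perhaps not beyond the scatter. The estimated step is a 1.6-fold lower number from compound 2 to compound 3 (0.21 log units; within the scatter). For compound 3 the expected value is 14000 nM, with an estimated range of 6500 nM to 30000 nM.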

Compound 3, half-maximal inhibitory concentration: 3600 nM
The estimate for compound 3 lay 3.9-fold (0.59 log units) above the measured number, and the stated range ends above it.
By their numbers in this assay, from the lowest: compounds 3 and 1 (each within the scatter of the next); then compound 2.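

Notes on the chain: in this assay the change from butyl to propyl, hydrogen in place of methyl on a saturated chain carbon, three bonds along the chain from an oxygen on a saturated carbon, gives a 6.3-fold lower number from compound 2 to compound 3 (0.80 log units; beyond the scatter) and so shows that this outer part of the chain is not a silent position. Going from the isopropyl group to the straight propyl chain gives a 1.9-fold lower number from compound 1 to compound 3 (0.27 log units; within the scatter) in the same assay, so these two groups cannot be told apart here, and branching at this oxygen shows no separate effect on the number. Of the three compounds, only the butyl compound 2 stands apart, which locates the earlier gap at the butyl chain rather than at the isopropyl group; no measurement shown here accounts for this step.

The compounds shown leave open whether the number stays level or moves again with a shorter chain such as ethyl or methyl, and whether a longer chain such as pentyl or hexyl follows butyl. They also leave open how an amine or a carboxylic acid at the end of the propyl chain would read in this assay on the shared core.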